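Adding a Third Methoxy Group: Expected Cytotoxicity of Compound 4

The source may report more compounds than this note shows. Statements on the series, on what has been measured and on what is new or still open speak of the compounds shown alone.

Of the compounds shown here, three sharing one core have been tested in a functional assay on MCF7 cells (Homo sapiens) for cytotoxicity, read by MTT assay, with a stated time of 48 h; a lower number here means a stronger inhibitor, a higher number a weaker inhibitor. Compound 1 `COc1cc(-c2cc(C(=O)Nc3nc4ccc(Cl)cc4s3)nc3cc(-c4ccccc4)nn23)cc(OC)c1OC` gives 30200 nM. In this assay compound 2 `COc1cc(-c2cc(C(=O)Nc3nc4ccc(F)cc4s3)nc3cc(-c4ccccc4)nn23)cc(OC)c1OC` gives 27500 nM. Going by the values given here, the only single-change step between measured compounds, a 1.1-fold lower number from compound 1 to compound 2 (0.04 log units; within the scatter), lies within the scatter. Compound 3 `COc1ccc2nc(NC(=O)c3cc(-c4ccc(OC)c(OC)c4)n4nc(-c5ccccc5)cc4n3)sc2c1` gives 18700 nM, the lowest of the three numbers, yet its gaps to compound 2 and to compound 1 are both within the scatter, so none of the three can be called stronger than another.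

Compound 4 `COc1ccc2nc(NC(=O)c3cc(-c4cc(OC)c(OC)c(OC)c4)n4nc(-c5ccccc5)cc4n3)sc2c1` differs from compound 3 by methoxy in place of hydrogen on an aromatic carbon. Among the compounds with values here, no measured step covers this change on its own: compounds 1 and 2 carry the 3,4,5-trimethoxyphenyl group but differ from compound 3 elsewhere as well, and their numbers sit within the scatter of the number for compound 3. With nothing pointing to a shift beyond the scatter, the step of a 1.3-fold higher number from compound 3 to compound 4 (0.11 log units; within the scatter) is expected to be small. Compound 4 is therefore estimated at 24000 nM, within a range from 9000 nM to 65000 nM.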

Compound 4, half-maximal inhibitory concentration: 2950 nM
Compound 4: the middle estimate sits 8.1-fold (0.91 log units) above what was measured; measured number outside the range, below it.
By their numbers in this assay, from the lowest: compound 4; then compounds 3, 2 and 1 (each within the scatter of the next).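

Going from 3,4-dimethoxyphenyl to 3,4,5-trimethoxyphenyl is the first change in this set to move the number beyond the scatter, with a 6.3-fold lower number from compound 3 to compound 4 (0.80 log units; beyond the scatter), so this position matters in a compound that already carries the methoxy group of compound 3. The site holding chloro or fluoro also matters with the 3,4,5-trimethoxyphenyl group in place: methoxy in place of fluoro gives a 9.3-fold lower number from compound 2 to compound 4 (0.97 log units; beyond the scatter), and methoxy in place of chloro gives a 10-fold lower number from compound 1 to compound 4 (1.01 log units; beyond the scatter), whereas fluoro in place of chloro gave only a 1.1-fold lower number from compound 1 to compound 2 (0.04 log units; within the scatter). Nothing available explains why these changes shift the number.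

The compounds shown leave open whether the lower number depends on methoxy itself at the new position, or whether ethoxy, hydroxyl or an amine there would give a similar number. They also leave open whether this step would appear with chloro or fluoro at the other site.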